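A few compounds are considered here, and "the series" means these few. Any claim that something is new, unique, unknown or untested is made for them only; others in the source may bear on it.

Measured so far:
Compound 1 `C/C(=C\C(=O)NC1CC1)c1cccc(F)c1`: 71 mg/kg
Compound 2 `CCNC(=O)/C=C1\CCc2ccc(F)cc21`: 136 mg/kg

Both numbers come from a functional assay on the whole organism with Mus musculus as the target, in the rotarod test; on this read-out lower numbers stand for an effect already at smaller amounts and higher numbers for an effect only at larger amounts of compound. Compound 2 sits within the usual scatter of compound 1, so these two values do not separate the two compounds. The two structures also differ in more than one place, so the pair says nothing about any single change.

Compound 3 `CC(C)NC(=O)/C=C1\CCc2ccc(F)cc21` keeps the core of compound 2, and its ethyl becomes isopropyl: methyl in place of hydrogen on a saturated chain carbon bound to an amide-type nitrogen and a saturated chain carbon. Put another way, a methyl takes the place of a hydrogen on a saturated chain carbon bound to an amide-type nitrogen and a saturated chain carbon. For the measured compounds named here, no measured pair here shows this kind of change, so the expectation rests only on compound 2 at 136 mg/kg and on how small the change is. No step beyond the scatter is expected in this assay, in either direction. The estimated 1.1-fold lower number from compound 2 to compound 3 (0.05 log units; within the scatter) is therefore small and lies within the scatter. For compound 3 the expected value is 120 mg/kg, with a range from 55 mg/kg to 270 mg/kg.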

Compound 3, dose for half-maximal effect: > 100 mg/kg
Compound 3 was reported as a limit; the forecaster's own chance of this, stated with the estimate: 10%; the middle value does not contradict the limit.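

In this assay, compound 3 is reported only as a limit, > 100 mg/kg, and not as a number. For the compounds shown here, no step from compound 2 to compound 3 can be read from this result. The compounds shown leave open whether replacing ethyl with isopropyl changes the dose needed for half-maximal effect at all, and in which direction.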